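This account rests on a few compounds, and the source may have more. Where it says the series, first, only, none or still open, it means among the compounds named here.

Compound 1 `COc1cccc2c1c(NS(=O)(=O)c1ccc(Cl)s1)nn2Cc1cc(CNC(C)=O)ccn1`: in an assay on isolated protein (blood) for antagonist activity at C-C chemokine receptor type 4 (Homo sapiens), read by flow cytometry, with a stated time of 30 min (a lower number here means tighter binding, a higher number weaker binding), compound 1 only reaches the assay limit of > 10000 nM, a limit rather than a number.
Compound 2 `COc1c(F)ccc2c1c(NS(=O)(=O)c1ccc(Cl)s1)nn2Cc1cccc(CNC(C)=O)c1`: in this assay compound 2 gives 3160 nM.

Within the data shown here, compound 2 therefore holds the only actual number here; the other value shown is a limit, as the limit of > 10000 nM in this assay, at which 1 of the 2 values shown sits, records. Among the measured compounds shown here, no two measured compounds differ in a single place, so no measured step can be read from them. Compound 3 `COc1c(F)ccc2c1c(NS(=O)(=O)c1ccc(Cl)s1)nn2Cc1cccc(CNC(=O)C(C)(C)O)c1` is the compound still to be measured. It differs from compound 2 by 1-hydroxy-1-methylethyl in place of methyl on a carbonyl carbon, so the acetamidomethyl arm becomes a (((1-hydroxy-1-methylethyl)carbonyl)amino)methyl arm. Nothing measured here says how such a change moves binding, so the expectation is a step in this assay with no clear direction and no larger than the usual scatter. The step expected here is a 1.3-fold lower number from compound 2 to compound 3 (0.10 log units; within the scatter). Compound 3 is thus estimated at 2500 nM, with a range from 800 nM to 8000 nM.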

Compound 3, dissociation constant in the C-C chemokine receptor type 4 assay: 631 nM
Compound 3: the middle estimate sits 4.0-fold (0.60 log units) above what was measured; the whole stated range lies above it.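

In the C-C chemokine receptor type 4 assay the carbonyl carbon of the side arm proves sensitive to what it carries: compound 2 gives 3160 nM and compound 3 gives 631 nM, so 1-hydroxy-1-methylethyl in place of methyl gives a 5.0-fold lower number from compound 2 to compound 3 (0.70 log units; beyond the scatter) and so tightens binding, with the entering group bringing a hydrogen-bond donor and acceptor that methyl lacks. In a physicochemical assay for lipophilicity (on this read-out lower numbers stand for lower lipophilicity and higher numbers for higher lipophilicity), compound 2 gives 4.1 and compound 3 gives 4.1, so the same swap gives no change at the digits printed from compound 2 to compound 3 (within the scatter) and so the tighter binding comes with no shift on that read-out. Nothing shown here accounts for why binding moved.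

Only this one swap is shown at this position, so it stays open whether the hydroxyl or the branched carbon framework carries the step. A tert-butyl group, which keeps the branching without the oxygen, or an amine in place of the hydroxyl, would help to separate the two.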